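Solubility in a nitro-trifluoromethyl piperazine amide series

This account rests on a few compounds, and the source may have more. Where it says the series, first, only, none or still open, it means among the compounds named here.

Among the measured compounds shown here, in a physicochemical assay for solubility, read by HPLC (a lower number here means a less soluble compound, a higher number a more soluble compound), compound 1 `O=C(c1cccc(F)c1)N1CCN(c2nc(=O)c3cc(C(F)(F)F)cc([N+](=O)[O-])c3s2)CC1` gives 0.2 ug/mL, and compound 2 `CCCC(=O)N1CCN(c2nc(=O)c3cc(C(F)(F)F)cc([N+](=O)[O-])c3s2)CC1` gives 2.46 ug/mL, the highest of the two numbers so far. For the measured compounds named here, the one step measured, a 12-fold higher number from compound 1 to compound 2 (1.09 log units; beyond the scatter), saw a ring leave the amide end. Compound 3 `O=C(CC1CCCCC1)N1CCN(c2nc(=O)c3cc(C(F)(F)F)cc([N+](=O)[O-])c3s2)CC1` reverses that pattern in kind: cyclohexyl in place of ethyl on a saturated chain carbon bound to a carbonyl carbon. Going by the values given here, since the sole step in this assay, a 12-fold higher number from compound 1 to compound 2 (1.09 log units; beyond the scatter), ran upward on removing a ring, a downward step is expected when a ring enters, of moderate size, a 4.9-fold lower number from compound 2 to compound 3 (0.69 log units; beyond the scatter). Compound 3 is estimated at 0.5 ug/mL, within 0.15 ug/mL to 1.6 ug/mL.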

Compound 3, solubility: 0.12 ug/mL
Compound 3: the middle estimate sits 4.2-fold (0.62 log units) above what was measured; measured number below the stated range.
By their numbers in this assay, from the lowest: compounds 3 and 1 (each within the scatter of the next); then compound 2.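

Cyclohexyl in place of ethyl on a saturated chain carbon bound to a carbonyl carbon gives a 21-fold lower number from compound 2 to compound 3 (1.31 log units; beyond the scatter) in this assay and so removes the whole of the gain seen with propyl. With a 1.7-fold lower number from compound 1 to compound 3 (0.22 log units; within the scatter) as the other new step, a non-aromatic ring and 3-fluorophenyl are not separated here, leaving the ring-free compound 2 alone at the top of the three. Nothing measured here accounts for these steps.
The compounds shown do not separate the presence of a ring from the added carbons, which a longer open chain such as pentyl would address. From the compounds shown here alone, how a ring carrying an amine or a carboxylic acid would read at this position also remains open.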